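The compounds below may be only part of what the source reports. "The series", "measured", "known", "first", "only" and "open" are said of these compounds alone.

In a functional assay on a cell-free system (plasma, Homo sapiens), with a stated time of 3 min (a lower number here means a stronger inhibitor, a higher number a weaker inhibitor), compound 1 (`CC(C)(C)OC[C@@H](O)C(=O)N1[C@H](C(=O)NCc2cc(Cl)ccc2-n2cnnn2)C[C@@H]2C[C@@H]21`) gives 500 nM as its reading. Compound 3 (`COC(C)(C)[C@@H](O)C(=O)N1C[C@H]2C[C@H]2[C@H]1C(=O)NCc1cc(Cl)ccc1-n1cnnn1`) gives 1000 nM in the same test. Compound 2 (`CC(C)(C)[C@@H](O)C(=O)N1OCC[C@H]1C(=O)NCc1cc(Cl)ccc1-n1cnnn1`) gives 1600 nM as its reading, which lies within the scatter of compound 3 and beyond the scatter from compound 1, on the side of the weaker inhibitor.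

Compound 4 (`CC(C)(C)C[C@@H](O)C(=O)N1OCC[C@H]1C(=O)NCc1cc(Cl)ccc1-n1cnnn1`) differs from compound 2 in one place, by neopentyl in place of tert-butyl on a saturated chain carbon bound to a carbonyl carbon and an oxygen on a saturated carbon in all: neopentyl in place of tert-butyl on a saturated chain carbon bound to a carbonyl carbon and an oxygen on a saturated carbon. For the measured compounds named here, no pair of measured compounds differs in one place only, so the data offer no direct guide to this change. A modest move toward a higher number in this assay is expected, and it may well stay within the scatter. The expected change is a 1.6-fold higher number from compound 2 to compound 4 (0.19 log units; within the scatter) on this estimate. Compound 4 is estimated at 2500 nM with an expected range of 800 nM to 8000 nM around that figure.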

Compound 4, half-maximal inhibitory concentration: 1100 nM
Beside the measured number, compound 4's estimate is 2.3-fold (0.36 log units) above it; low and high end bracket the measured number.
By their numbers in this assay, from the lowest: compounds 1, 3, 4 and 2 (each within the scatter of the next, the first and the last beyond it).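

For the compounds shown here, the step from tert-butyl to neopentyl is the only one here that changes a single place, and it gives a 1.5-fold lower number from compound 2 to compound 4 (0.16 log units; within the scatter) in this assay. At this saturated chain carbon bound to a carbonyl carbon and an oxygen on a saturated carbon, the group thus grows from 4 to 5 heavy atoms, with no ring, donor or acceptor entering, and the reading does not move beyond the scatter. No measurement shown here accounts for this result.

The compounds shown do not tell how a group such as an amine, a carboxylic acid or a phenyl ring would read at this position. They also leave open whether neopentyl in place of tert-butyl would behave the same way on the core of compound 1 or of compound 3.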